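The source may hold more compounds than are shown below. What is called first, only, known or untested is meant among the compounds shown, and "the series" means these compounds.

Measured compounds:
Compound 1, `NS(=O)(=O)c1ccc(Nc2nccc(-c3ccccn3)n2)cc1`, gives 4600 nM in a functional assay for inhibition, with Homo sapiens as the target; a higher number here means a weaker inhibitor, a lower number a stronger inhibitor.
Compound 2, `CN(C)c1ccc(Nc2nccc(-c3ccccn3)n2)cc1`, gives 3300 nM.
Compound 3, `CC1CCN(c2ccc(Nc3nccc(-c4ccccn4)n3)cc2)CC1`, gives 1900 nM.

Among these three numbers compound 2 stands second highest. Its nearest neighbour is compound 1, with a 1.4-fold lower number from compound 1 to compound 2 (0.14 log units; within the scatter), and its furthest is compound 3, with a 1.7-fold lower number from compound 2 to compound 3 (0.24 log units; within the scatter); both of these gaps fall within the scatter of repeat measurements, so the three compounds cannot be ranked with confidence against one another. Among the measured compounds shown here, only the step of a 2.4-fold lower number from compound 1 to compound 3 (0.38 log units; beyond the scatter) reaches beyond the scatter, and even that is modest.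

Compound 4, `CN(C)c1ccc(Nc2nccc(-c3cccs3)n2)cc1`, has not yet been measured. It differs from compound 2 in one place: thiophen-2-yl in place of pyridin-2-yl on an aromatic carbon. All three measured steps concern a different part of the shared core, the group on the aromatic carbon that carries sulfamoyl, dimethylamino or 4-methylpiperidin-1-yl, while the pyridin-2-yl is kept in every measured compound. No measured step therefore bears on the exchange of pyridin-2-yl for thiophen-2-yl, and the small spread of the three measured values gives no reason to expect a large shift in either direction. The expected step is a 1.4-fold higher number from compound 2 to compound 4 (0.13 log units; within the scatter), with a wide range to reflect the missing precedent. Compound 4 is estimated at 4500 nM, between 1500 nM and 14000 nM.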

Compound 4, half-maximal inhibitory concentration: 900 nM
Estimate against measurement, compound 4: 5.0-fold (0.70 log units) above; the measured number lies below the stated range.
By their numbers in this assay, from the lowest: compound 4; then compounds 3, 2 and 1 (each within the scatter of the next, the first and the last beyond it).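

Among the compounds shown here, until now only one other group on the shared core had varied, so this is the first sign that the place held by pyridin-2-yl also matters in this assay, where thiophen-2-yl instead gives a 3.7-fold lower number from compound 2 to compound 4 (0.56 log units; beyond the scatter). That modest step lies beyond the scatter, whereas exchanging dimethylamino for 4-methylpiperidin-1-yl gives a 1.7-fold lower number from compound 2 to compound 3 (0.24 log units; within the scatter), which stays within it, so here the ring exchange is the clearer of the two changes made to compound 2. The exchange swaps a six-membered ring holding a nitrogen for a five-membered ring holding a sulfur, and no measurement available here separates these differences or explains the lower number.

As far as these compounds go, it remains open whether thiophen-2-yl would lower the number in the same way alongside 4-methylpiperidin-1-yl or sulfamoyl, which would show whether the two places on the core act independently. From the compounds shown here alone, it is also open whether the sulfur matters or any other ring would serve, a question that phenyl, furan-2-yl, thiophen-3-yl or pyridin-3-yl in the same place could help to answer.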